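Guanidine ureas at the histamine H2 receptor: a propyl chain grows

A few compounds are considered here, and "the series" means these few. Any claim that something is new, unique, unknown or untested is made for them only; others in the source may bear on it.

Measured so far:
compound 1, `CCCNC(=O)/N=C(\N)NCCCc1sc(N)nc1C`: 170 nM
compound 2, `Cc1nc(N)sc1CCCN/C(N)=N/C(=O)NC(c1ccccc1)c1ccccc1`: 331 nM
compound 3, `Cc1nc(N)sc1CCCN/C(N)=N/C(=S)N[C@H](C)c1ccccc1`: 372 nM

All three share one core and differ only in the group carried on the urea or thiourea end. In a functional assay on HEK293T cells for agonist activity at histamine H2 receptor (Homo sapiens), read by beta-arrestin recruitment (on this read-out higher numbers stand for an effect only at larger amounts of compound and lower numbers for an effect already at smaller amounts), compound 1 gives 170 nM; compound 2 cannot be told apart from it within the usual scatter, while compound 3 sits beyond the scatter above compound 1. Compound 4, `Cc1nc(N)sc1CCCN/C(N)=N/C(=O)NCC(C)CC1CCCCC1`, has not yet been tested in this assay. It differs from compound 1 by cyclohexylmethyl in place of hydrogen on a saturated chain carbon bound to two saturated chain carbons. Since compound 2 and compound 3 carry large groups in this position and stay close to compound 1, the step from compound 1 to compound 4 is expected to be small, a 1.2-fold higher number from compound 1 to compound 4 (0.09 log units; within the scatter), with no direction that would clearly exceed the scatter. Compound 4 is therefore estimated at 210 nM, within 70 nM to 650 nM.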

Compound 4, half-maximal effective concentration: 302 nM
Compound 4: the middle estimate sits 1.4-fold (0.16 log units) below what was measured; measured number inside the range.
By their numbers in this assay, from the lowest: compounds 1, 4, 2 and 3 (each within the scatter of the next, the first and the last beyond it).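

Within the data shown here, compound 4 gives the first direct comparison at this position: in this assay, cyclohexylmethyl in place of hydrogen on a saturated chain carbon bound to two saturated chain carbons gives a 1.8-fold higher number from compound 1 to compound 4 (0.25 log units; within the scatter). So adding 7 heavy atoms, including a six-membered ring of carbon only, leaves a step that cannot be told from the scatter of repeated measurements. No measurement shown here offers an explanation for this result.

Open, from the compounds shown here alone, is whether a longer chain with no ring would match cyclohexylmethyl. Also open, going by these compounds, is whether an amine or a carboxylic acid on this chain would stay as close to compound 1.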